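Acetamido in place of 4-methylphenyl: expected step

The source may hold more compounds than are shown below. What is called first, only, known or untested is meant among the compounds shown, and "the series" means these compounds.

In a functional assay on MCF7 cells (Homo sapiens) for cytotoxicity, read by sulforhodamine B assay, with a stated time of 24 h (a lower number here means a stronger inhibitor, a higher number a weaker inhibitor), compound 1 (`Cc1ccc(/N=C2\C(=O)Nc3ccc(S(=O)(=O)N4CCOCC4)cc32)cc1`) gives 55900 nM, and compound 2 (`COc1ccc(-c2c(C#N)c(N)n(/N=C3\C(=O)Nc4ccc(S(=O)(=O)N5CCOCC5)cc43)c(=O)c2C#N)cc1`) gives 33400 nM. Going by the values given here, these two values lie within the scatter of each other, so compound 1 stands level with the only other measured compound. Compound 3 (`CC(=O)N/N=C1\C(=O)Nc2ccc(S(=O)(=O)N3CCOCC3)cc21`) keeps the core of compound 1 but has acetamido in place of 4-methylphenyl on a double-bonded nitrogen. Among the compounds with values here, no measured pair isolates this change, so the expectation rests on thin evidence. Compound 2 carries a different group on that nitrogen and gives 33400 nM, so no large shift is expected for compound 3. The expected step of a 1.2-fold lower number from compound 1 to compound 3 (0.09 log units; within the scatter) in this assay is none beyond the scatter. For compound 3 the estimate is 45000 nM, with an expected range of 18000 nM to 110000 nM.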

Compound 3, half-maximal inhibitory concentration: 56000 nM
The estimate for compound 3 lay 1.2-fold (0.09 log units) below the measured number; low and high end bracket the measured number.
By their numbers in this assay, from the lowest: compounds 2, 1 and 3 (each within the scatter of the next).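

Acetamido in place of 4-methylphenyl on a double-bonded nitrogen gives a 1.0-fold higher number from compound 1 to compound 3 (0.00 log units; within the scatter) in this assay, and this is the only pair shown that isolates a change at this position. The change removes the six-membered aromatic ring of carbon only, brings in a hydrogen-bond donor and a hydrogen-bond acceptor, and reduces the heavy-atom count, yet the read-out does not move beyond the scatter, so this aromatic ring is not required to retain this level of cytotoxicity. No available measurement accounts for this flat step.

From the compounds shown here alone, whether an amine, a carboxylic acid or a longer chain on that nitrogen would shift the number beyond the scatter remains open. Also open, going by these compounds, is whether any change to the shared core would do so.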